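Bromo in Place of Hydrogen, Carried Onto a Second Core

This account rests on a few compounds, and the source may have more. Where it says the series, first, only, none or still open, it means among the compounds named here.

Compound 1, `O=C(NCCO)c1cc2ccc(OCc3ccccc3)cc2oc1=O`: 18700 nM
Compound 2, `O=C(NCCO)c1cc2ccc(OCc3cccc(Br)c3)cc2oc1=O`: 30800 nM
Compound 3, `NNC(=O)c1cc2ccc(OCc3ccccc3)cc2oc1=O`: a limit of the assay, > 100000 nM

In a functional assay on HCT-116 cells (Homo sapiens) for cytotoxicity, read by MTT assay, with a stated time of 72 h (on this read-out lower numbers stand for stronger inhibition and higher numbers for weaker inhibition), compound 1 and compound 2 differ by one change, (bromo in place of hydrogen on an aromatic carbon), and the step is a 1.6-fold higher number from compound 1 to compound 2 (0.22 log units; within the scatter). Compound 3 is the second core; it differs from compound 1 by amino in place of 2-hydroxyethyl on an amide-type nitrogen, and the step is an at least 5.3-fold higher number from compound 1 to compound 3 (0.72 log units; beyond the scatter). For compound 3 only a limit is recorded, (the limit of > 100000 nM in this assay, at which 1 of the 3 values shown sits).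

Compound 4, `NNC(=O)c1cc2ccc(OCc3cccc(Br)c3)cc2oc1=O`, is not yet measured in this assay. It carries the same change onto compound 3 as compound 2 carries onto compound 1: bromo in place of hydrogen on an aromatic carbon. The place line reads the same in both cases, so this is the same change.

In this assay the step from compound 3 to compound 4 is expected to be a step that the limit leaves unreadable from compound 3 to compound 4, resting on the size of a 1.6-fold higher number from compound 1 to compound 2 (0.22 log units; within the scatter). Compound 4 is therefore estimated at 150000 nM, between 70000 nM and 350000 nM, and is expected most likely to come back as a limit, as compound 3 did at the limit of > 100000 nM in this assay, at which 1 of the 3 values shown sits.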

Compound 4, half-maximal inhibitory concentration: > 100000 nM
Compound 4 was reported as a limit (the forecaster's own chance of this, stated with the estimate: 85%); the middle value does not contradict the limit.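

In this assay, compound 4 is reported as a limit, as compound 3 was, so the step between them cannot be read and the data give no size for bromo in place of hydrogen on the second core. The other new step can be read: amino in place of 2-hydroxyethyl on an amide-type nitrogen gives an at least 3.2-fold higher number from compound 2 to compound 4 (0.51 log units; beyond the scatter), so this change raises the number with the bromo group present as well as without it. Set beside the earlier step, this shows the same direction on both cores but no firm size for either: the same change on two cores in this assay, an at least 5.3-fold higher number (0.72 log units; beyond the scatter) from compound 1 to compound 3 and an at least 3.2-fold higher number (0.51 log units; beyond the scatter) from compound 2 to compound 4; the limit leaves it open whether they differ.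

Left open is how a longer chain or an amine in place of 2-hydroxyethyl on the amide-type nitrogen would read in this assay, and how chloro or methoxy in place of bromo would read on the core of compound 1. Also open, from the compounds shown here alone, is whether any change to the core of compound 3 would give a value that can be read as a number.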